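Fluoro for Trifluoromethyl on a Thioether-Linked Propargylamine

A few compounds are considered here, and "the series" means these few. Any claim that something is new, unique, unknown or untested is made for them only; others in the source may bear on it.

Three compounds have been measured in an ADME assay on isolated protein for inhibition of Amine oxidase [flavin-containing] B (Homo sapiens); on this read-out higher numbers stand for weaker inhibition and lower numbers for stronger inhibition:

Compound 1, `C#CCNC1CCc2c(OCc3cccc(C(F)(F)F)c3)cccc21`, gives 5410 nM.
Compound 2, `C#CCNC1CCc2c(SCc3cccc(F)c3)cccc21`, gives 11600 nM.
Compound 3, `C#CCNC1CCc2c(SCCc3cccc(C(F)(F)F)c3)cccc21`, gives 280 nM.

Among these three, compound 3 stands lowest in this assay, and its distance to compound 1, the nearest of the other two, as well as to compound 2, the furthest, lies beyond the scatter of the assay. Compound 3 is therefore the strongest inhibitor of the set shown here. No pair of these compounds differs in a single place, so the numbers of compound 1 and compound 2 show only that both sit well above compound 3.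

Compound 4, `C#CCNC1CCc2c(SCCc3cccc(F)c3)cccc21`, has not yet been measured. It differs from compound 3 in one place: fluoro in place of trifluoromethyl on an aromatic carbon. For the measured compounds named here, the set holds no measured pair that isolates this change, so the expectation rests on the position of compound 3 alone. For compound 4 a modest rise in the number is expected, with a step of a 2.5-fold higher number from compound 3 to compound 4 (0.40 log units; beyond the scatter) in this assay, though a result within the scatter of compound 3 would not be surprising. The estimate for compound 4 in this assay is 700 nM, with a range from 200 nM to 2500 nM.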

Compound 4, half-maximal inhibitory concentration: 7810 nM
Beside the measured number, compound 4's estimate is 11-fold (1.05 log units) below it, outside the stated range (above it).
By their numbers in this assay, from the lowest: compound 3; then compounds 1, 4 and 2 (each within the scatter of the next, the first and the last beyond it).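

In this assay, for the compounds shown here, putting fluoro in place of trifluoromethyl on this aromatic carbon gives a 28-fold higher number from compound 3 to compound 4 (1.45 log units; beyond the scatter), a large step and the first reading of this change, which no earlier pair could isolate. The two compounds differ only in this group. The step ties the low number of compound 3 to the trifluoromethyl group at this place: the shared core and the chain, both kept in compound 4, do not alone preserve it. Going by these compounds alone, nothing measured here explains why this one change moves the number so far.

The compounds shown hold only these two groups at this place, so it remains open how a chloro, methyl or methoxy group would stand there, and whether the number follows a gradual trend between fluoro and trifluoromethyl or turns on trifluoromethyl alone. Going by these compounds, it also remains open whether the same change would weigh as heavily on the chain of compound 1, or whether its size belongs to the chain that compound 3 and compound 4 share.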